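A few compounds are considered here, and "the series" means these few. Any claim that something is new, unique, unknown or untested is made for them only; others in the source may bear on it.

In an assay on microsomes from brain for inhibition of Fatty-acid amide hydrolase 1 (Rattus norvegicus), read by fluorescence and HPLC, with a stated time of 60 min (a higher number here means a weaker inhibitor, a lower number a stronger inhibitor), compound 1 `CCCCCCCCc1ccc(OCC(=O)Cn2nnc(SC)n2)cc1` gives 31 nM. In this assay compound 2 `CCCCCCCCc1ccc(OCC(=O)Cn2nnc(-c3ccccc3)n2)cc1` gives 24 nM, and the step of a 1.3-fold lower number from compound 1 to compound 2 (0.11 log units; within the scatter) shows that these two numbers sit within the scatter of each other, so neither stands apart from the other. Compound 3 `CCCCCCCCc1ccc(OCC(=O)Cn2nnc(-c3ccc(Cl)cc3)n2)cc1` carries chloro in place of hydrogen on an aromatic carbon; read one bond further out, the change is phenyl to 4-chlorophenyl. Going by the values given here, no measured step involves a chloro on this ring, and the only step known was small, so no step beyond the scatter is expected. Compound 3 is therefore estimated at 20 nM, between 8 nM and 50 nM, which would mean a 1.2-fold lower number from compound 2 to compound 3 (0.08 log units; within the scatter).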

Compound 3, half-maximal inhibitory concentration: 35 nM
The estimate for compound 3 lay 1.8-fold (0.24 log units) below the measured number; low and high end bracket the measured number.
By their numbers in this assay, from the lowest: compounds 2, 1 and 3 (each within the scatter of the next).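

In this assay, adding a chloro to the phenyl group gives a 1.5-fold higher number from compound 2 to compound 3 (0.16 log units; within the scatter) and so shows that this six-membered aromatic ring can carry a chlorine atom with no step beyond the scatter. Replacing methylsulfanyl with 4-chlorophenyl gives a 1.1-fold higher number from compound 1 to compound 3 (0.05 log units; within the scatter) and so shows that all three groups tried on this aromatic carbon of the shared core read alike. No measured evidence offers an explanation for this.

On these data alone, it remains open whether an amine or a carboxylic acid in place of the chloro would produce a step beyond the scatter. As far as these compounds go, it also remains open whether a chloro elsewhere on this ring would read the same.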